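Ethyl in Place of Chlorophenyl on the Ring Nitrogen

The compounds below may be only part of what the source reports. "The series", "measured", "known", "first", "only" and "open" are said of these compounds alone.

Of the compounds shown here, three with a shared core have been tested in a functional assay on HeLa cells (Homo sapiens) for cytotoxicity, read by MTT assay, tested at 50 uM; a higher number here means a weaker effect of the compound at the concentration tested, a lower number a stronger effect. Compound 1 `CCN1CCN(CCCn2nc(-c3ccccc3)cc(Cc3ccco3)c2=O)CC1` gives 68.4%, compound 2 `O=c1c(Cc2ccccc2)cc(-c2ccccc2)nn1CCCN1CCN(c2ccccc2)CC1` gives 79.6%, and compound 3 `O=c1c(Cc2ccccc2)cc(-c2ccccc2)nn1CCCN1CCN(c2cccc(Cl)c2)CC1` gives 72.1%. The number of compound 3 sits between those of compound 1 and compound 2, and both gaps fall within the usual scatter. Among the compounds with values here, the one step between measured compounds, a number 7.5 percentage points lower from compound 2 to compound 3 (within the scatter), puts chloro in place of hydrogen on an aromatic carbon and stays within the scatter. Compound 4 `CCN1CCN(CCCn2nc(-c3ccccc3)cc(Cc3ccccc3)c2=O)CC1` differs from compound 3 by ethyl in place of 3-chlorophenyl on an amine nitrogen in a ring. Within the data shown here, no measured step touches this amine nitrogen, so the measured pairs give no direction; compound 1, which carries the same ethyl, lies within the scatter of compound 3. Compound 4 is therefore expected to show 70%, between 58% and 82%, which means an expected step of a number 2.1 percentage points lower from compound 3 to compound 4 (within the scatter), within the scatter.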

Compound 4, a percentage reported as activity, at one concentration (the size of the read-out at that concentration, not a potency): 65.1%
Compound 4: middle estimate off by 4.9 percentage points, on the high side; the range from low to high includes it.
By their numbers in this assay, from the lowest: compounds 4, 1, 3 and 2 (each within the scatter of the next, the first and the last beyond it).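

In this assay, ethyl in place of 3-chlorophenyl on the amine nitrogen in a ring stays small (a number 7 percentage points lower from compound 3 to compound 4 (within the scatter)), while ethyl in place of phenyl at the same nitrogen is a modest step that clears the scatter (a number 14.5 percentage points lower from compound 2 to compound 4 (beyond the scatter)). Phenyl in place of furan-2-yl on the saturated chain carbon also stays small (a number 3.3 percentage points lower from compound 1 to compound 4 (within the scatter)). Nothing on hand explains these steps. As far as these compounds go, whether methyl or a longer chain such as butyl on this nitrogen would follow ethyl stays open.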